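Working notes: fluoro in place of methoxy

A few compounds are considered here, and "the series" means these few. Any claim that something is new, unique, unknown or untested is made for them only; others in the source may bear on it.

Measured values in a functional assay on L1210 cells (Mus musculus) for inhibition (a lower number here means a stronger inhibitor, a higher number a weaker inhibitor), so far:
- compound 1 `O=C1/C(=C/c2ccccc2Br)CCCc2ccccc21` gives 37000 nM
- compound 2 `O=C1/C(=C/c2ccccc2Cl)CCCc2ccccc21` gives 42300 nM
- compound 3 `COc1ccccc1/C=C1\CCCc2ccccc2C1=O` gives 46100 nM

At 46100 nM compound 3 cannot be told apart from the other two compounds, since both of its steps stay within the scatter.

The next compound is compound 4 `O=C1/C(=C/c2ccccc2F)CCCc2ccccc21` and the change is fluoro in place of methoxy on an aromatic carbon which amounts to fluoro in place of methoxy on an aromatic carbon, ortho to a large group.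

Within the data shown here, three measured steps bear on this change, all exchanges at the same place: a 1.1-fold higher number from compound 1 to compound 2 (0.06 log units; within the scatter) then a 1.2-fold higher number from compound 1 to compound 3 (0.10 log units; within the scatter) and a 1.1-fold higher number from compound 2 to compound 3 (0.04 log units; within the scatter) with none of them beyond the scatter. Bromo, chloro and methoxy therefore give no measurable difference here. Among the measured compounds shown here, no measured compound carries fluoro, so this rests on the other three groups alone.

On the strength of a 1.1-fold higher number from compound 2 to compound 3 (0.04 log units; within the scatter) no step beyond the scatter is expected in this assay in either direction. The expected step is a 1.1-fold lower number from compound 3 to compound 4 (0.03 log units; within the scatter) and it is estimated without a favoured direction.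

For compound 4 the estimate is 43000 nM with an expected range from 24000 nM to 75000 nM in these notes.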

Compound 4, half-maximal inhibitory concentration: 60400 nM
For compound 4 the middle estimate is 1.4-fold (0.15 log units) below the measured one; the range from low to high includes it.
By their numbers in this assay, from the lowest: compounds 1, 2, 3 and 4 (each within the scatter of the next).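

In this assay, fluoro now joins bromo, chloro and methoxy on this aromatic carbon, ortho to a large group, and none of its three new steps leaves the scatter (a 1.3-fold higher number from compound 3 to compound 4 (0.12 log units; within the scatter); a 1.4-fold higher number from compound 2 to compound 4 (0.15 log units; within the scatter); a 1.6-fold higher number from compound 1 to compound 4 (0.21 log units; within the scatter)). This extends the flat picture from three groups to four, and the widest of the new steps, the one from bromo to fluoro, still cannot be read as a real difference, so the four compounds have no order in this assay. The change from methoxy to fluoro also drops the hydrogen-bond acceptor counted for methoxy and leaves a group with fewer heavy atoms, yet the numbers stay within the scatter, and no measurement at hand accounts for this sameness.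

The compounds shown leave open whether an amine, a carboxylic acid or a longer chain on this aromatic carbon would give a step beyond the scatter. They also leave open whether these four groups would read alike elsewhere on the same aromatic ring, as every exchange shown stays at this one place.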